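The source may report more compounds than this note shows. Statements on the series, on what has been measured and on what is new or still open speak of the compounds shown alone.

Measured so far:
Compound 1, `CCCCNc1nc(N)nc2c1CN(Cc1ccncc1)CC2`, in an assay on HEK293 cells for agonist activity at Toll-like receptor 8 (Homo sapiens), read by a luciferase reporter, with a stated time of 6 h (a higher number here means that more compound is needed for the effect, a lower number that less compound is needed), gives 0.29 uM.
Compound 2, `CCCCNc1nc(N)nc2c1CN(Cc1ccco1)CC2`, in this assay gives 0.08 uM.

Compound 2 has the lowest number of the two, and its nearest neighbour is compound 1, the step being a 3.6-fold lower number from compound 1 to compound 2 (0.56 log units; beyond the scatter). Compound 3, `CCCCNc1nc(N)nc2c1CN(C(=O)c1cscn1)CC2`, differs from compound 2 in one place: (1,3-thiazol-4-yl)carbonyl in place of (furan-2-yl)methyl on an amine nitrogen in a ring. Within the data shown here, the only measured step swaps one ring for another while the saturated chain carbon stays; the step into compound 3 also replaces that carbon with a carbonyl, and no measured pair shows what such a change does. Among the measured compounds shown here, the one step seen, from compound 1 to compound 2, was modest, so a change of similar size or somewhat larger seems plausible, with the direction open. A somewhat higher number than that of compound 2 is expected for compound 3, a 6.3-fold higher number from compound 2 to compound 3 (0.80 log units; beyond the scatter), with wide uncertainty. For compound 3 in this assay the expected value is 0.5 uM, within a range from 0.08 uM to 3 uM.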

Compound 3, minimum effective concentration: 0.5 uM
Estimate against measurement, compound 3: no gap at the digits printed; the measured number falls inside the stated range.
By their numbers in this assay, from the lowest: compound 2; then compounds 1 and 3 (each within the scatter of the next).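

Among these compounds, on the amine nitrogen in a ring, (1,3-thiazol-4-yl)carbonyl in place of (furan-2-yl)methyl gives, in this assay, a 6.3-fold higher number from compound 2 to compound 3 (0.80 log units; beyond the scatter), so this is the first sign that a group joined through a carbonyl can still give a sub-micromolar-range reading here, though more compound is needed than with the furan. Against (pyridin-4-yl)methyl, the same group gives a 1.7-fold higher number from compound 1 to compound 3 (0.24 log units; within the scatter), which leaves the furan compound alone with the lowest number of the three. No measurement at hand explains either step.

The ring and the link changed at once in both steps, and the compounds shown do not separate the two; a (furan-2-yl)carbonyl group on this nitrogen would do so. Also open, going by these compounds, is what a plain phenyl ring or a short alkyl chain would give at this position.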